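A few compounds are considered here, and "the series" means these few. Any claim that something is new, unique, unknown or untested is made for them only; others in the source may bear on it.

Working notes on the series. Compound 1 `N#Cc1c(-c2nnc(-c3ccccc3)c3nn(-c4ccccc4)cc23)nn(-c2ccccc2)c1-c1ccccc1` gives 32800 nM in a functional assay on SK-OV-3 cells (Homo sapiens) for inhibition, read by sulforhodamine B assay, with a stated time of 48 h; a higher number here means a weaker inhibitor of growth, a lower number a stronger inhibitor of growth. Compound 2 `N#Cc1c(-c2nnc(-c3ccccc3)c3nn(-c4ccc(Cl)cc4)cc23)nn(-c2ccccc2)c1-c1ccccc1` gives > 100000 nM in this assay, and this is a limit of the assay, not a number. Compound 3 `Cc1ccc(-n2cc3c(-c4nn(-c5ccccc5)c(-c5ccccc5)c4C#N)nnc(-c4ccccc4)c3n2)cc1` has not yet been measured. Its structure departs from that of compound 2 as follows: methyl in place of chloro on an aromatic carbon. In words, this is methyl in place of chloro on an aromatic carbon, para to a large group, so that 4-chlorophenyl becomes 4-methylphenyl.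

Among the compounds with values here, one measured step bears on this change: an at least 3.0-fold higher number from compound 1 to compound 2 (0.48 log units; beyond the scatter). That step, chloro in place of hydrogen on an aromatic carbon, lies beyond the scatter. Within the data shown here, no measured compound carries methyl at this place, so any forecast for it is weakly supported. With compound 1 at 32800 nM as the hydrogen reference, a modest step toward a lower number is expected, no larger than the measured one. The expected move is an at least 1.8-fold lower number from compound 2 to compound 3 (0.25 log units; that floor lies within the scatter). Compound 3 is estimated at 55000 nM, with an expected range from 18000 nM to 130000 nM.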

Compound 3, concentration for 50% growth inhibition: 9720 nM
Compound 3: middle estimate off by 5.7-fold (0.75 log units), on the high side; the measured number lies below the stated range.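

In this assay the first pair showed only a loss on substitution at this place, but substitution there need not weaken growth inhibition, since methyl in place of hydrogen gives a 3.4-fold lower number from compound 1 to compound 3 (0.53 log units; beyond the scatter) and lies beyond the scatter. The change from 4-chlorophenyl to 4-methylphenyl gives an at least 10-fold lower number from compound 2 to compound 3 (1.01 log units; beyond the scatter) and is large, so with one heavy atom entering and one leaving, what counts at this place is which group sits there, not merely whether the hydrogen is replaced. Compound 2 stands at a limit and not at a number, so the full size of that step cannot be read: the limit of > 100000 nM in this assay, at which 1 of the 3 values shown sits.

Chloro and methyl are the only two substituents shown on this aromatic carbon, and with so few the series gives no trend, leaving open whether methoxy, an amine, a carboxylic acid or a longer chain such as ethyl would follow methyl or chloro. Also open, on these data alone, is whether the gain seen with methyl carries over to the other phenyl groups on the shared core.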